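From Ethyl to Phenyl: Compound 2 to Compound 4

A few compounds are considered here, and "the series" means these few. Any claim that something is new, unique, unknown or untested is made for them only; others in the source may bear on it.

Measured so far in a functional assay on MIA PaCa-2 cells (Homo sapiens) for antiproliferative activity, read by colorimetric assay (on this read-out higher numbers stand for weaker inhibition and lower numbers for stronger inhibition), are:
compound 1 `Cc1nc2c(s1)C(O)=C/C(=N\CCN(C)C)C2=O` at 180 nM
compound 2 `CCc1nc2c(o1)C(O)=C/C(=N\CCN(C)C)C2=O` at 440 nM
compound 3 `CN(C)CC/N=C1\C=C(O)c2nc(-c3ccccc3)oc2C1=O` at 150 nM

Compound 2 holds the highest number of the three, and so shows the weakest inhibition. Its gaps to compound 1 and to compound 3 both lie beyond the scatter, and the gap to compound 3 is the wider one.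

Compound 4 `CN(C)CC/N=C1\C=C(O)c2oc(-c3ccccc3)nc2C1=O` has not yet been measured. It differs from compound 2 by phenyl in place of ethyl on an aromatic carbon. Within the data shown here, no measured pair shows this change on its own, so the expectation rests on indirect evidence. Compound 3 also carries phenyl and gives 150 nM in this assay on a differently arranged core, which offers a guide but no direct comparison. Among the measured compounds shown here, with only three measured compounds, the support is thin.

A modest step toward stronger inhibition is expected (a 2.2-fold lower number from compound 2 to compound 4 (0.34 log units; beyond the scatter)), and it may stay close to the scatter. The expected value for compound 4 is 200 nM within a range of 80 nM to 480 nM as estimated here.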

Compound 4, half-maximal inhibitory concentration: 150 nM
The estimate for compound 4 lay 1.3-fold (0.12 log units) above the measured number; low and high end bracket the measured number.
By their numbers in this assay, from the lowest: compounds 3, 4 and 1 (each within the scatter of the next); then compound 2.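

In this assay, phenyl in place of ethyl on the aromatic carbon next to the ring nitrogen and next to the ring oxygen gives a 2.9-fold lower number from compound 2 to compound 4 (0.47 log units; beyond the scatter) as a modest step toward stronger inhibition, and that step lies beyond the scatter. Among these compounds, this is the first pair in the set that differs in one place, so the position now has a direct reading: it accepts a six-membered aromatic ring of carbon in place of ethyl, and inhibition grows stronger rather than being lost. The compounds offer no accompanying measurement that accounts for this gain, so the step stands as an observation without an explanation.

The compounds shown leave open whether the gain belongs to the aromatic ring itself or simply to a larger group, which a longer chain such as butyl or a saturated ring such as cyclohexyl at the same carbon could separate. They also leave open how this position would respond to a phenyl ring bearing an amine or a carboxylic acid, or to a methyl group in place of ethyl on this same core.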